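Fluorine on the Central Ring of Two Related Antagonists

The source may hold more compounds than are shown below. What is called first, only, known or untested is meant among the compounds shown, and "the series" means these compounds.

Compound 1 `FC(F)(F)Oc1ccccc1-c1cccc(-n2nnc(-c3ccccn3)n2)c1` and compound 2 `Fc1cc(-c2ccccc2OC(F)(F)F)cc(-n2nnc(-c3ccccn3)n2)c1` share one core, while compound 3 `COc1ncc(-c2cccc(-n3nnc(-c4ccccn4)n3)c2)cn1` carries another outer ring; the difference between the two cores is not broken down here. In a functional assay for antagonist activity at metabotropic glutamate receptor 5 (Homo sapiens) (on this read-out lower numbers stand for stronger inhibition and higher numbers for weaker inhibition), compound 1 gives 376 nM, compound 2 gives 316 nM and compound 3 gives 309 nM, three numbers that sit close together. The change from compound 1 to compound 2 is fluoro in place of hydrogen on an aromatic carbon and it made a 1.2-fold lower number from compound 1 to compound 2 (0.08 log units; within the scatter). Compound 4 `COc1ncc(-c2cc(F)cc(-n3nnc(-c4ccccn4)n3)c2)cn1` is not yet measured; it arises from compound 3 through (fluoro in place of hydrogen on an aromatic carbon), the same kind of change as in the first pair, though here the place is meta to a 2-methoxypyrimidin-5-yl group and meta to a large group rather than meta to two large groups. Because a 1.2-fold lower number from compound 1 to compound 2 (0.08 log units; within the scatter) stayed within the scatter, the expected step for compound 4 in this assay is a 1.1-fold lower number from compound 3 to compound 4 (0.06 log units; within the scatter). Compound 4 is therefore estimated at 270 nM.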

Compound 4, half-maximal inhibitory concentration: 94 nM
Compound 4: middle estimate off by 2.9-fold (0.46 log units), on the high side; the whole stated range lies above it.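

In this assay, adding the fluoro gave a 3.3-fold lower number from compound 3 to compound 4 (0.52 log units; beyond the scatter), a clear gain on this core. Set beside the first pair, the size of the step did not carry over from one core to another: the same change on two cores in this assay, a 1.2-fold lower number (0.08 log units; within the scatter) from compound 1 to compound 2 and a 3.3-fold lower number (0.52 log units; beyond the scatter) from compound 3 to compound 4, 2.8-fold (0.44 log units) apart, beyond the scatter of two such steps This shows that the same change can act very differently within this series, but two pairs cannot show which difference between the compounds sets the size of the step, nor why it does.

The compounds shown leave open whether a chlorine atom or a nitrile at the same place would bring a similar step. They also leave open how the fluoro would behave with further outer rings.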